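Swapping the fused heteroaryl of compound 3 for bromophenyl

The source may hold more compounds than are shown below. What is called first, only, known or untested is meant among the compounds shown, and "the series" means these compounds.

Three compounds share one core and differ only in the group on one amide-type nitrogen. In a functional assay on HCT-116 cells (Homo sapiens) for inhibition, read by colorimetric assay, with a stated time of 3 days (a lower number here means a stronger inhibitor, a higher number a weaker inhibitor), compound 1 `O=C(CCCCCCNC(=O)C(O)(O)C(F)(F)F)Nc1nccs1` gives 10800 nM, compound 2 `O=C(CCCCCCNC(=O)C(O)(O)C(F)(F)F)Nc1nc2ccc(Br)cc2o1` gives 12100 nM, and compound 3 `O=C(CCCCCCNC(=O)C(O)(O)C(F)(F)F)Nc1nc2ccccc2s1` gives 2370 nM. Among the compounds with values here, compound 3 thus stands lowest of the three numbers, and the single one-place step measured so far, a 4.6-fold lower number from compound 1 to compound 3 (0.66 log units; beyond the scatter), is modest yet beyond the scatter.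

Compound 4 `O=C(CCCCCCNC(=O)C(O)(O)C(F)(F)F)Nc1cccc(Br)c1` arises from compound 3 through one change: 3-bromophenyl in place of 1,3-benzothiazol-2-yl on an amide-type nitrogen. Within the data shown here, no measured step bears directly on this exchange: the step from compound 1 to compound 3 concerns a different pair of groups, and compound 2, which also carries a bromine, differs from compound 3 in more than one place. Among the measured compounds shown here, the expectation therefore rests on the spread of the three numbers and on the modest size of the only step seen. Compound 4 is expected to show a 3.4-fold higher number from compound 3 to compound 4 (0.53 log units; beyond the scatter), a move toward a higher number. Compound 4 is estimated at 8000 nM, within a range from 2500 nM to 25000 nM.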

Compound 4, half-maximal inhibitory concentration: 3060 nM
Beside the measured number, compound 4's estimate is 2.6-fold (0.42 log units) above it; low and high end bracket the measured number.
By their numbers in this assay, from the lowest: compounds 3 and 4 (each within the scatter of the next); then compounds 1 and 2 (each within the scatter of the next).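

In this assay, within the data shown here, the two-ring 1,3-benzothiazol-2-yl group turns out not to be the only group on this amide-type nitrogen that gives a number at this level, for a 1.3-fold higher number from compound 3 to compound 4 (0.11 log units; within the scatter) is a step inside the scatter, although a single carbon ring bearing bromine has taken its place. The 3-bromophenyl group also stands clear of the smaller 1,3-thiazol-2-yl group, with a 3.5-fold lower number from compound 1 to compound 4 (0.55 log units; beyond the scatter), so the hetero atoms and hydrogen-bond acceptors of the leaving group are not required for a number at this level. No evidence given here explains these numbers.

As far as these compounds go, what the bromine itself contributes stays open, and a plain phenyl or a 3-chlorophenyl group on this nitrogen would address it. From the compounds shown here alone, how a carboxylic acid or an amine on the ring would read at this place also remains unknown.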